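The source may report more compounds than this note shows. Statements on the series, on what has been measured and on what is new or still open speak of the compounds shown alone.

Measured in a functional assay on the whole organism (Tail, strain ICR) with Mus musculus as the target, in the tail flick test, with a stated time of 30 min, at a dose of 25 umol/kg by the oral route; a higher number here means a stronger effect of the compound at the dose given, a lower number a weaker effect:
compound 1 `O=C(CN(c1ncnc2c1ncn2C1CCCCO1)C1CC1)N[C@@H](CO)C(=O)OCc1ccccc1` gives 27.8%;
compound 2 `CSCC[C@H](NC(=O)CN(c1nc(Cl)nc2[nH]cnc12)C1CC1)C(=O)OCc1ccccc1` gives 22.2%;
compound 3 `CC[C@H](C)[C@H](NC(=O)CN(c1ncnc2c1ncn2C1CCCCO1)C1CC1)C(=O)OCc1ccccc1` gives 25.6%.

Compound 2 has the lowest of the three numbers, yet its gaps to compound 3 and to compound 1 both lie within the usual scatter, so the three compounds cannot be ranked against each other. The change from compound 2 to compound 4 `O=C(CN(c1nc(Cl)nc2[nH]cnc12)C1CC1)N[C@@H](CCC(=O)OCc1ccccc1)C(=O)OCc1ccccc1` is benzyloxycarbonyl in place of methylsulfanyl on a saturated chain carbon, three bonds along the chain from an amide-type nitrogen and a carbonyl carbon. For the measured compounds named here, the only measured step, a number 2.2 percentage points lower from compound 1 to compound 3 (within the scatter), exchanges a different group and stays within the scatter, so no step directly informs this change. The step from compound 2 to compound 4 is therefore expected to stay within the scatter, a number 0.2 percentage points lower from compound 2 to compound 4 (within the scatter). Compound 4 is estimated at 22%, between 12% and 32%.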

Compound 4, a percentage reported as activity, at one dose (the size of the read-out at that dose, not a potency): 52.8%
Beside the measured number, compound 4's estimate is 30.8 percentage points below it; measured number outside the range, above it.
By their numbers in this assay, from the lowest: compounds 2, 3 and 1 (each within the scatter of the next); then compound 4.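

In this assay, the chain carbon three bonds along from an amide-type nitrogen and a carbonyl carbon proves sensitive to what it carries: with benzyloxycarbonyl in place of methylsulfanyl, there is a number 30.6 percentage points higher from compound 2 to compound 4 (beyond the scatter). The only earlier step stayed within the scatter, so this is the first change shown to move the number. No measured evidence here bears on what lies behind this rise.

The compounds shown leave open whether the aromatic ring or the ester matters. A carboxylic acid or a methyl ester at this place would help separate the two.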